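The source may report more compounds than this note shows. Statements on the series, on what has been measured and on what is new or still open speak of the compounds shown alone.

Measured so far:
compound 1 `Cc1c(C(=O)Nc2c(F)cc(-c3cccc(F)c3)cc2F)nc2ccc(C(F)(F)F)cc2c1O` — 45.2%
compound 2 `Cc1c(C(=O)Nc2c(F)cc(-c3cccc(F)c3)cc2F)nc2ccc(F)cc2c1C(=O)O` — 34.3%

In a functional assay on Hep 3B2 cells (Homo sapiens) for antiproliferative activity, read by MTT assay, with a stated time of 24 h, tested at 33.33 ug/mL (a higher number here means a stronger effect of the compound at the concentration tested, a lower number a weaker effect), compound 1 gives 45.2%. In this assay compound 2 gives 34.3%, the lower of the two numbers; its nearest neighbour is compound 1, whose number stands higher by a gap beyond the usual scatter. Going by the values given here, the two compounds differ in more than one place, so no single step connects them and the gap cannot be assigned to either difference.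

Compound 3 `Cc1c(C(=O)Nc2c(F)cc(-c3cccc(F)c3)cc2F)nc2ccc(C(F)(F)F)cc2c1C(=O)O` is still to be measured in this assay. Against compound 2 the change is trifluoromethyl in place of fluoro on an aromatic carbon. Among the compounds with values here, no step of this kind between measured compounds exists. Compound 1 carries the same trifluoromethyl and gives 45.2%, but since it also differs elsewhere from compound 2, this is weak ground. In this assay a modest upward step is expected, possibly within the scatter; the estimated step is a number 5.7 percentage points higher from compound 2 to compound 3 (within the scatter). For compound 3 the estimate is 40%, with a range from 26% to 54%.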

Compound 3, a percentage reported as inhibition, at one concentration (the size of the read-out at that concentration, not a potency): 43.3%
Compound 3: middle estimate off by 3.3 percentage points, on the low side, within the range that was stated.
By their numbers in this assay, from the lowest: compounds 2, 3 and 1 (each within the scatter of the next, the first and the last beyond it).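

In this assay the exchange of fluoro for trifluoromethyl on the aromatic carbon now has a reading in a single place (a number 9 percentage points higher from compound 2 to compound 3 (within the scatter)), and so does carboxy in place of hydroxy (a number 1.9 percentage points lower from compound 1 to compound 3 (within the scatter)). Both steps lie within the scatter, so neither exchange alone is separated from no change at all, although compound 1 and compound 2, which differ in both places, stand apart by more than the scatter. Nothing measured on these compounds bears on the reason for these readings.

Open, as far as these compounds go, is whether a different group on this aromatic carbon, such as an amine, a methoxy group or a nitrile, would give a step beyond the scatter. From the compounds shown here alone, the read-out comes from one concentration, so the size of the effect of compound 1, compound 2 and compound 3 at other concentrations also remains open.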